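Swapping chloro for cyano on compound 1

This account rests on a few compounds, and the source may have more. Where it says the series, first, only, none or still open, it means among the compounds named here.

Compound 1 `O=C(CCS(=O)(=O)c1cccc2ncsc12)N1CCN(c2ccc(Cl)cn2)CC1`: 31%
Compound 2 `Cc1cc(F)cnc1N1CCN(C(=O)CCCc2cccc3ncccc23)[C@@H](C)C1`: 0.2%
Compound 3 `Cc1cc(F)cnc1N1CCN(C(=O)CCCc2cccc3ncncc23)[C@@H](C)C1`: 0%

All three compounds were measured in an ADME assay on microsomes from liver (Rattus norvegicus) for metabolic stability, read by LC-MS, with a stated time of 15 min, tested at 1 uM; on this read-out higher numbers stand for a more stable compound and lower numbers for a less stable compound. Compound 1 stands highest of the three, and the gaps from it to compound 2 and compound 3 both lie beyond the usual scatter of this kind of measurement.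

The next compound to be measured is compound 4 `N#Cc1ccc(N2CCN(C(=O)CCS(=O)(=O)c3cccc4ncsc34)CC2)nc1`, which keeps the core of compound 1 and changes one group: cyano in place of chloro on an aromatic carbon. In other words, 5-chloropyridin-2-yl becomes 5-cyanopyridin-2-yl.

Within the data shown here, only one measured step changes a single place: a number 0.2 percentage points lower from compound 2 to compound 3 (within the scatter). It places quinazolin-5-yl where quinolin-5-yl stood, a different change at a different place, and both of its values lie at the very bottom of the scale. Among the measured compounds shown here, it therefore offers little guidance here, and no measured pair shows chloro replaced by cyano. With no evidence for a direction, no shift beyond the scatter is expected in this assay. The expected step is a number 2 percentage points higher from compound 1 to compound 4 (within the scatter). For compound 4 the estimated value is 33%, with an expected range from 13% to 58%.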

Compound 4, percent of the compound remaining: 59%
Compound 4: the middle estimate sits 26 percentage points below what was measured; the whole stated range lies below it.
By their numbers in this assay, from the lowest: compounds 3 and 2 (each within the scatter of the next); then compound 1; then compound 4.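

In this assay, putting cyano in place of chloro gives a number 28 percentage points higher from compound 1 to compound 4 (beyond the scatter), with the rest of the molecule unchanged. This shows that the aromatic carbon two atoms from the ring nitrogen is a place where exchanging one small group can move the number by more than repeated measurements would, at least on this core. Among these compounds, the earlier compounds could not show this, as their only single-place step, a number 0.2 percentage points lower from compound 2 to compound 3 (within the scatter), concerns a different change at a different place and sits at the very bottom of the scale, and nothing available here speaks to why the number rises.

Going by these compounds, whether the rise is particular to cyano remains open, since a single pair cannot say how other groups at this place, such as fluoro, methyl, trifluoromethyl or a primary carboxamide, would compare with chloro and cyano. Also open, on these data alone, is whether the same swap would raise the number on a different core, as this step rests on compound 1 and compound 4 alone.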